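The compounds below may be only part of what the source reports. "The series", "measured", "known", "first", "only" and "open" are said of these compounds alone.

Measured in a physicochemical assay for solubility, read by HPLC, measured as kinetic solubility, at pH 7; on this read-out lower numbers stand for lower solubility and higher numbers for higher solubility:
- compound 1, `O=C(Nc1ccc(OC(F)(F)F)cc1)N[C@@H]1COc2nc([N+](=O)[O-])cn2C1`, gives 93 ug/mL
- compound 2, `O=C(NCc1ccc(OC(F)(F)F)cc1)N[C@@H]1COc2nc([N+](=O)[O-])cn2C1`, gives 32 ug/mL
- compound 3, `O=C(Nc1ccc(-c2ccc(OC(F)(F)F)cc2)cc1)N[C@@H]1COc2nc([N+](=O)[O-])cn2C1`, gives 0.17 ug/mL

Compound 1 and compound 3 share a core and differ in one place: 4-(trifluoromethoxy)phenyl in place of trifluoromethoxy on an aromatic carbon. That single change carried a 550-fold lower number from compound 1 to compound 3 (2.74 log units; beyond the scatter), so compound 3 ends far down among the three measured compounds.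

Compound 2 stands on a different core from compound 1; how the two cores differ is not broken down here. In this assay compound 2 gives a number lower than compound 1, and both lie well above compound 3.

Compound 4, `O=C(NCc1ccc(-c2ccc(OC(F)(F)F)cc2)cc1)N[C@@H]1COc2nc([N+](=O)[O-])cn2C1`, has not yet been measured. It stands to compound 2 as compound 3 stands to compound 1, since the change is the same: 4-(trifluoromethoxy)phenyl in place of trifluoromethoxy on an aromatic carbon. Because the same change gave a 550-fold lower number from compound 1 to compound 3 (2.74 log units; beyond the scatter), a step of comparable size is expected from compound 2 to compound 4, namely a 400-fold lower number from compound 2 to compound 4 (2.60 log units; beyond the scatter). That expectation rests on one measured pair only, so the size may differ on the core of compound 2, and a number near the floor of what the measurement reports is possible. Compound 4 is therefore estimated at 0.08 ug/mL, with a range from 0.015 ug/mL to 0.5 ug/mL.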

Compound 4, solubility: 0.94 ug/mL
Compound 4: the middle estimate sits 12-fold (1.07 log units) below what was measured, and the stated range ends below it.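

In this assay, the change from trifluoromethoxy to 4-(trifluoromethoxy)phenyl again gave a lower number on the core of compound 2 (a 34-fold lower number from compound 2 to compound 4 (1.53 log units; beyond the scatter)), in the same direction as on the core of compound 1 (a 550-fold lower number from compound 1 to compound 3 (2.74 log units; beyond the scatter)), and both steps are large and beyond the scatter. The direction therefore carried from one core to the other, while the size did not carry over intact, since the step printed for the core of compound 2 is the smaller of the two. With only these two matched pairs, this does not establish a rule for other cores in the series or predict how large the step would be on a third core, and no measurement shown here accounts for the difference in size between the two steps.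

The compounds shown leave open how the number would move if an amine or a carboxylic acid stood in place of trifluoromethoxy on the added aromatic ring of compound 4. They also leave open whether a longer chain in place of the single carbon that separates the core of compound 2 from its aromatic ring would give a step closer to one of the two seen here.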